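Chloro removal on the anilino ring of compound 2

A few compounds are considered here, and "the series" means these few. Any claim that something is new, unique, unknown or untested is made for them only; others in the source may bear on it.

Measured so far in a functional assay on PC-3 cells (Homo sapiens) for cytotoxicity, read by MTT assay; on this read-out higher numbers stand for weaker inhibition and lower numbers for stronger inhibition:
compound 1, `COc1cc(/C=C/C(=O)c2sc(Nc3ccccc3C)nc2C)cc(OC)c1OC`, gives > 25000 nM, a limit of the assay.
compound 2, `COc1cccc(/C=C/C(=O)c2sc(Nc3ccc(Cl)c(Cl)c3)nc2C)c1`, gives 10100 nM.
compound 3, `COc1ccc(/C=C/C(=O)c2sc(Nc3ccc(Cl)c(Cl)c3)nc2C)cc1`, gives > 25000 nM, a limit of the assay.

For the measured compounds named here, compound 2 thus holds the only number among the three results; the other two sit at the same limit, (the limit of > 25000 nM in this assay, at which 2 of the 3 values shown sit). Going by the values given here, the one counted step, an at least 2.4-fold higher number from compound 2 to compound 3 (0.39 log units; beyond the scatter), concerns the methoxyphenyl side of the chain and not the anilino ring, so it does not speak directly to the change considered here.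

Compound 4, `COc1cccc(/C=C/C(=O)c2sc(Nc3cccc(Cl)c3)nc2C)c1`, is not yet measured in this assay. It differs from compound 2 by hydrogen in place of chloro on an aromatic carbon. Among the compounds with values here, no measured pair in the set varies the anilino ring alone, so there is no direct guide to the size of this step. Given that compound 2 stands close to the limit already, and that a small group is removed, the expectation is a step of modest size or none beyond the scatter, with weakening the more likely direction: the estimate for compound 4 is 16000 nM, between 6000 nM and 40000 nM, corresponding to a 1.6-fold higher number from compound 2 to compound 4 (0.20 log units; within the scatter) as the expected step.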

Compound 4, half-maximal inhibitory concentration: > 25000 nM
Compound 4 gave a limit, no number (the forecaster's own chance of this, stated with the estimate: 35%); middle value at least 1.5-fold (0.19 log units) away from the limit.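

In this assay the anilino ring now has its first direct comparison: the change from 3,4-dichlorophenyl to 3-chlorophenyl, with hydrogen in place of chloro on an aromatic carbon para to a large group, comes with an at least 2.4-fold higher number from compound 2 to compound 4 (0.39 log units; beyond the scatter). Compound 4 gives > 25000 nM, which is a limit of the assay and not a number. Alongside an at least 2.4-fold higher number from compound 2 to compound 3 (0.39 log units; beyond the scatter), this is a second single change that ends at the limit, so the anilino ring as well as the methoxyphenyl side now shows a change that loses the measurable value, and only a lower bound on the size of each step is known: the limit of > 25000 nM in this assay, at which 3 of the 4 values shown sit.

Still open, as far as these compounds go, is whether chloro itself matters at this place or whether another group, such as bromo or trifluoromethyl, would hold or improve the value of compound 2. Also open, from the compounds shown here alone, is what removing the other chloro alone would do, and whether any change to the anilino ring can give a lower number than compound 2 shows.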